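The source may hold more compounds than are shown below. What is called first, only, known or untested is meant among the compounds shown, and "the series" means these compounds.

Measured compounds:
- compound 1 `CN1CCC(c2ccc3c(c2)oc(=O)n3C(=O)NCCCCc2ccccc2)CC1=O`: 105 nM
- compound 2 `CCCCCNC(=O)n1c(=O)oc2cc(-c3ccc(F)cc3)ccc21`: 60 nM
- compound 3 `CC(C)CNC(=O)n1c(=O)oc2cc(C3CCCCN3C)ccc21`: 1010 nM

In an assay on HEK293 cells for inhibition of acid ceramidase (Homo sapiens), read by fluorescence, with stated times of 10 min and 3 h (on this read-out higher numbers stand for weaker inhibition and lower numbers for stronger inhibition), compound 1 gives 105 nM, the second highest of the three numbers. Compound 2 gives 60 nM, which lies within the scatter of compound 1, so no order between the two can be read from these numbers. Compound 3 gives 1010 nM, a number well beyond the scatter above compound 1, but compound 3 differs from compound 1 in more than one place, so what drives that gap cannot be told apart here.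

Compound 4 `CCN1CCN(c2ccc3c(c2)oc(=O)n3C(=O)NCCCCc2ccccc2)CC1` has not yet been measured in this assay. It keeps the shared core and the side chain of compound 1 and differs only in 4-ethylpiperazin-1-yl in place of 1-methyl-2-oxopiperidin-4-yl on an aromatic carbon. Within the data shown here, no pair of measured compounds differs in only this way, so there is no measured step to lean on. Since the rest of the molecule is unchanged, the step is expected to be small, with no clear direction beyond the scatter; the estimate puts the step at a 1.4-fold higher number from compound 1 to compound 4 (0.15 log units; within the scatter). Compound 4 is therefore expected to give about 150 nM, within a range from 50 nM to 500 nM.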

Compound 4, half-maximal inhibitory concentration: 56 nM
Beside the measured number, compound 4's estimate is 2.7-fold (0.43 log units) above it; low and high end bracket the measured number.
By their numbers in this assay, from the lowest: compounds 4, 2 and 1 (each within the scatter of the next); then compound 3.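

In this assay, among these compounds, the first comparison at this position with the side chain held fixed gives a 1.9-fold lower number from compound 1 to compound 4 (0.27 log units; within the scatter). The aromatic carbon that is meta to a fused ring and para to a fused ring can therefore carry either 1-methyl-2-oxopiperidin-4-yl or 4-ethylpiperazin-1-yl, a ring with two nitrogens and no carbonyl, and these numbers cannot order the two groups. Nothing given here bears on why the two groups give values within the scatter of each other.

The compounds shown leave open how a morpholin-4-yl ring, or a piperazine without the ethyl group, would read at this position. They also leave open whether the two rings would remain this close if a pentyl chain replaced the side chain of compound 1.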